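A few compounds are considered here, and "the series" means these few. Any claim that something is new, unique, unknown or untested is made for them only; others in the source may bear on it.

The measured compounds:
compound 1, `CC(C)=CC[C@@H](OC[C@@H](C)O)C1=CC(=O)c2c(O)ccc(O)c2C1=O`, gives 14300 nM in a functional assay on DU-145 cells (Homo sapiens) for cytotoxicity, read by MTT assay; a lower number here means a stronger inhibitor, a higher number a weaker inhibitor
compound 2, `COC(C)CO[C@H](CC=C(C)C)C1=CC(=O)c2c(O)ccc(O)c2C1=O`, gives 16600 nM
compound 3, `CC(C)=CC[C@@H](OC(=O)CC(C)(O)c1ccccc1)C1=CC(=O)c2c(O)ccc(O)c2C1=O`, gives > 100000 nM, a limit of the assay and not a number

Among the compounds with values here, compounds 1 and 2 carry an ether side chain on the shared core, and the only measured step, a 1.2-fold higher number from compound 1 to compound 2 (0.06 log units; within the scatter), concerns that ether side chain. Compound 3 instead carries an ester side chain and sits at the limit of > 100000 nM in this assay, at which 1 of the 3 values shown sits, so its true value is not known beyond that bound.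

Compound 4, `CCCC(O)CC(=O)O[C@H](CC=C(C)C)C1=CC(=O)c2c(O)ccc(O)c2C1=O`, keeps the ester of compound 3 but differs in the group on the saturated chain carbon bound to the carbonyl carbon: 1-hydroxybutyl in place of 1-hydroxy-1-phenylethyl on a saturated chain carbon bound to a carbonyl carbon. Within the data shown here, no measured step touches this ester side chain, so nothing among the three measured compounds sets the size or direction of the change.

Because compound 3 stands at the limit of > 100000 nM in this assay, at which 1 of the 3 values shown sits, compound 4 is expected to stay weak, with a step of an at least 1.6-fold lower number from compound 3 to compound 4 (0.22 log units; that floor lies within the scatter) that is only a guess. Compound 4 is therefore estimated at 60000 nM, within 20000 nM to 150000 nM.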

Compound 4, half-maximal inhibitory concentration: > 100000 nM
Compound 4 gave a limit, no number; the forecaster's own chance of this, stated with the estimate: 50%; middle value at least 1.6-fold (0.22 log units) from the limit.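

On these data alone, replacing 1-hydroxy-1-phenylethyl with 1-hydroxybutyl removes the aromatic ring, yet compound 4, like compound 3, stands at a limit of this assay and not at a number: the limit of > 100000 nM in this assay, at which 2 of the 4 values shown sit. The step between these two esters cannot be read, so the change in this group shows no measurable gain, though any difference hidden past the limit stays unknown. Changing the side chain on the oxygen from an ether to the ester of compound 4 gives an at least 6.0-fold higher number from compound 2 to compound 4 (0.77 log units; beyond the scatter) and an at least 6.9-fold higher number from compound 1 to compound 4 (0.84 log units; beyond the scatter), so among the compounds shown, both esters fall on the weak side of both ethers.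

Still open, as far as these compounds go, is how far past the limit the true values of compound 3 and compound 4 lie. From the compounds shown here alone, it is also open whether an ester with a terminal amine or carboxylic acid on its chain, or an amide link in place of the ester, would return a readable number.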